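Hydrogen in place of chloro, starting from a limit

This account rests on a few compounds, and the source may have more. Where it says the series, first, only, none or still open, it means among the compounds named here.

Compound 1 `Cc1cc(C)nc(SCc2cc(=O)c3cc(Cl)ccc3o2)n1` was tested in a functional assay on MCF7 cells (Homo sapiens) for cytotoxicity, read by MTT assay, with a stated time of 72 h; a lower number here means a stronger inhibitor, a higher number a weaker inhibitor. In this assay compound 1 gives > 25000 nM, which is a limit of the assay. Compound 2 `Cc1nnc(SCc2cc(=O)c3cc(Cl)ccc3o2)o1` has a different core; the difference between the two cores is not broken down here. In this assay compound 2 gives > 25000 nM, a limit. Compound 3 `Cc1nnc(SCc2cc(=O)c3ccccc3o2)o1` arises from compound 2 by hydrogen in place of chloro on an aromatic carbon and in this assay compound 3 gives > 25000 nM, a limit as well. The step that the two limits leave unreadable from compound 2 to compound 3 cannot be read because of the limit of > 25000 nM in this assay, at which 3 of the 3 values shown sit. Compound 4 `Cc1cc(C)nc(SCc2cc(=O)c3ccccc3o2)n1` stands to compound 1 through the same change, (hydrogen in place of chloro on an aromatic carbon). The expected step is a step that the limit leaves unreadable from compound 1 to compound 4, resting on the unreadable step that the two limits leave unreadable from compound 2 to compound 3 that compound 3 shows. Compound 4 is therefore estimated at 40000 nM.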

Compound 4, half-maximal inhibitory concentration: > 25000 nM
Compound 4 ended at the assay's limit (the forecaster's own chance of this, stated with the estimate: 90%); the middle value is on the limit's open side.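

No new step can be read between compound 1 and compound 4, because both values are limits: the limit of > 25000 nM in this assay, at which 4 of the 4 values shown sit. The compounds shown leave open whether hydrogen in place of chloro changes the read-out in this assay for any of them.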